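A few compounds are considered here, and "the series" means these few. Any claim that something is new, unique, unknown or untested is made for them only; others in the source may bear on it.

In a functional assay on BHK-21 cells (Mesocricetus auratus) for cytotoxicity, read by MTT assay (a lower number here means that less compound is tolerated, a higher number that more compound is tolerated), compound 1 `O=C(c1ccccc1)N1N=C(c2cccs2)CC1c1ccc(Cl)cc1` gives > 300000 nM, which is a limit and not a number. Compound 2 `O=C(c1ccccc1)N1N=C(c2cccs2)CC1c1ccc(Br)cc1`, with bromo in place of chloro on an aromatic carbon, gives > 300000 nM, again a limit. The series therefore offers only (the limit of > 300000 nM in this assay, at which 2 of the 2 values shown sit).

Compound 3 `O=C(c1ccc([N+](=O)[O-])cc1)N1N=C(c2cccs2)CC1c1ccc(Cl)cc1` differs from compound 1 by nitro in place of hydrogen on an aromatic carbon, the change being from phenyl to 4-nitrophenyl. Among the compounds with values here, the one measured step, a step that the two limits leave unreadable from compound 1 to compound 2, has no usable size and involves a different change. Within the data shown here, no measured compound carries nitro, so the expectation rests on the limit shared by compound 1 and compound 2. A value at or close to that limit is expected, with any readable shift more likely toward less compound tolerated. The expected step is an at least 1.2-fold lower number from compound 1 to compound 3 (0.07 log units; that floor lies within the scatter). For compound 3 the estimated value is 250000 nM, with an expected range of 90000 nM to 400000 nM.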

Compound 3, half-maximal cytotoxic concentration: > 300000 nM
Compound 3 ended at the assay's limit; the forecaster's own chance of this, stated with the estimate: 60%; at least 1.2-fold (0.07 log units) between middle value and limit.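

In this assay compound 3 gives > 300000 nM, a limit and not a number. No step among compound 1, compound 2 and compound 3 can be read: the limit of > 300000 nM in this assay, at which 3 of the 3 values shown sit.

Going by these compounds, open remains whether bromo or nitro changes the tolerated concentration at all, since the true values of all three compounds remain unknown.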